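Halogen swap on the benzoyl ring of the shared core

The source may report more compounds than this note shows. Statements on the series, on what has been measured and on what is new or still open speak of the compounds shown alone.

Three members of the series have numbers in a functional assay on DLA cells (Mus musculus) for cytotoxicity, read by trypan blue exclusion, with a stated time of 48 h (a lower number here means a stronger inhibitor, a higher number a weaker inhibitor), so far. Compound 1 `Cc1ccc(OCC(=O)NNC(=O)c2cc3ccccc3oc2=O)c(C(=O)c2cccc(Cl)c2)c1` gives 68600 nM there. Compound 2 `Cc1ccc(OCC(=O)NNC(=O)c2cc3ccccc3oc2=O)c(C(=O)c2ccccc2Br)c1` gives 10000 nM in this assay. Compound 3 `Cc1ccc(OCC(=O)NNC(=O)c2cc3ccccc3oc2=O)c(C(=O)c2ccc(Br)cc2)c1` gives 95500 nM in this assay, the highest of the three numbers; its gap to compound 1 is within the scatter, whereas a 9.6-fold higher number from compound 2 to compound 3 (0.98 log units; beyond the scatter) is beyond it, as is a 6.9-fold lower number from compound 1 to compound 2 (0.84 log units; beyond the scatter). Compound 4 `Cc1ccc(OCC(=O)NNC(=O)c2cc3ccccc3oc2=O)c(C(=O)c2ccc(F)cc2)c1` is the next one to go into this assay. It differs from compound 3 by fluoro in place of bromo on an aromatic carbon. Among the compounds with values here, no measured step changes the halogen alone at one place: a 1.4-fold higher number from compound 1 to compound 3 (0.14 log units; within the scatter) moves the halogen to another aromatic carbon while swapping it, and stays within the scatter. Within the data shown here, only the step to the 2-bromophenyl compound 2 was beyond the scatter. For compound 4 the step is therefore expected to stay within the scatter, a 1.1-fold lower number from compound 3 to compound 4 (0.03 log units; within the scatter), and compound 4 is estimated at 90000 nM, between 30000 nM and 270000 nM.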

Compound 4, half-maximal inhibitory concentration: 46100 nM
Compound 4: middle estimate off by 2.0-fold (0.29 log units), on the high side, and the stated range covers the measured number.
By their numbers in this assay, from the lowest: compound 2; then compounds 4, 1 and 3 (each within the scatter of the next, the first and the last beyond it).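

Within the data shown here, the step of a 2.1-fold lower number from compound 3 to compound 4 (0.32 log units; beyond the scatter) in this assay is the first to change the halogen alone at one place, para to a large group, and it lies beyond the scatter, so the identity of the halogen can register here. That step remains small beside a 4.6-fold higher number from compound 2 to compound 4 (0.66 log units; beyond the scatter), and compound 2 still has the lowest number of the four, while the 4-fluorophenyl and 3-chlorophenyl compounds stay level, a 1.5-fold lower number from compound 1 to compound 4 (0.17 log units; within the scatter). Nothing available explains the difference between bromo and fluoro at this place.

From the compounds shown here alone, whether the lower number of compound 2 belongs to the bromo group or to its place on the ring stays open. Also open, going by these compounds, is how a non-halogen group, such as an amine or a methoxy group, would read at the place held by fluoro in compound 4.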